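One Benzyl Group Swapped for Another in Compound 3

The compounds below may be only part of what the source reports. "The series", "measured", "known", "first", "only" and "open" are said of these compounds alone.

In a functional assay on L6 cells (Rattus norvegicus) for inhibition (a lower number here means a stronger inhibitor, a higher number a weaker inhibitor), compound 3 (`COCc1cccc(CNC(=O)c2nn(-c3ccc(F)cc3)c(OC[C@@H](O)C[C@@H](O)CC(=O)O)c2C(C)C)c1`) gives 3600 nM. Among the measured compounds shown here, its only measured neighbour, compound 1 (`CC(C)c1c(C(=O)N2CCCC2c2ccccc2)nn(-c2ccc(F)cc2)c1OC[C@@H](O)C[C@@H](O)CC(=O)O`), gives 4340 nM, and these two numbers lie within the scatter of each other, so neither can be called the better inhibitor. For a third relative, compound 2 (`CC(C)c1c(C(=O)NCc2ccccn2)nn(-c2ccc(F)cc2)c1OC[C@@H](O)C[C@@H](O)CC(=O)O`), the entry reads "not determined" (no result reported).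

Compound 4 (`CC(C)c1c(C(=O)NCc2ccccc2Cl)nn(-c2ccc(F)cc2)c1OC[C@@H](O)C[C@@H](O)CC(=O)O`) keeps the shared core and alters a single group. The change is 2-chlorophenyl in place of 3-(methoxymethyl)phenyl on a saturated chain carbon bound to an amide-type nitrogen. Put another way, 3-(methoxymethyl)benzyl gives way to 2-chlorobenzyl on the amide nitrogen.

For the measured compounds named here, only one measured step offers guidance: a 1.2-fold lower number from compound 1 to compound 3 (0.08 log units; within the scatter). That step replaced the whole group on the carbonyl carbon, yet the number stayed within the scatter. Going by the values given here, this is thin evidence, since it is a single step and no measured compound here carries the 2-chlorobenzyl group.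

On that basis, no shift beyond the scatter is expected in this assay, and the expected step is a 1.0-fold lower number from compound 3 to compound 4 (0.01 log units; within the scatter). For compound 4, the estimated value is 3500 nM, with an expected range from 1000 nM to 11000 nM, kept wide to reflect how little the data can show.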

Compound 4, half-maximal inhibitory concentration: 8450 nM
Compound 4: the middle estimate sits 2.4-fold (0.38 log units) below what was measured; the range from low to high includes it.
By their numbers in this assay, from the lowest: compounds 3, 1 and 4 (each within the scatter of the next, the first and the last beyond it).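

In this assay, the group on the amide nitrogen proves able to move the number: a 2.3-fold higher number from compound 3 to compound 4 (0.37 log units; beyond the scatter) is a modest step, but unlike the earlier step from compound 1 to compound 3, it passes beyond the usual scatter. The comparison with the differently built amide of compound 1 remains unresolved, as a 1.9-fold higher number from compound 1 to compound 4 (0.29 log units; within the scatter) does not separate those two compounds, so the chlorinated compound 4 can be told apart only from compound 3. Nothing measured here explains why the swap shifts the number.

The swap removes a methoxymethyl chain, with its hydrogen-bond acceptor, and adds a chlorine in a single step, so the compounds shown cannot tell whether losing the chain, gaining the chlorine, or both produced the change. A plain benzyl group, carrying neither feature, would separate these two parts of the swap, and a methyl group or a bromine in place of the chlorine on 2-chlorobenzyl would show whether the chlorine itself matters.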